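The compounds below may be only part of what the source reports. "The series", "measured", "known", "first", "only" and "open" are said of these compounds alone.

Measured compounds in an assay on isolated protein for inhibition of Nicotinamide phosphoribosyltransferase (Homo sapiens), read by fluorescence, with stated times of 5 min and 15 min; a higher number here means a weaker inhibitor, a lower number a stronger inhibitor:

Compound 1 `Nc1ccccc1NC(=O)c1ccc(CNC(=O)c2cc3cccnc3[nH]2)cc1` gives > 2000 nM, which is a limit of the assay.
Compound 2 `Nc1ccccc1NC(=O)c1ccc(NC(=S)NCc2ccc(Cl)nc2)cc1` gives > 2000 nM, again a limit.
Compound 3 `Nc1ccccc1NC(=O)c1ccc(CNC(=O)c2cc3cnccc3[nH]2)cc1` gives > 2000 nM, once more a limit.

Among the measured compounds shown here, compound 2 therefore stands where every value so far stands: at the limit of > 2000 nM in this assay, at which 3 of the 3 values shown sit, with no number of its own. For the measured compounds named here, the one step that can be read between measured compounds, a step that the two limits leave unreadable from compound 1 to compound 3, is itself unreadable, as both of its ends are limits.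

Compound 4 `Nc1ccccc1NC(=O)c1ccc(NC(=S)NCc2cccnc2)cc1` differs from compound 2 by hydrogen in place of chloro on an aromatic carbon. Going by the values given here, no measured step bears on this kind of change: the only step available, from compound 1 to compound 3, concerns a different part of the molecule and its size is not readable. What is known is that compound 2 gives no number in this assay and that the same holds for both of its companions.

The expectation for compound 4 rests on that alone: it is estimated to sit in the same region as compound 2, with a step that the limit leaves unreadable from compound 2 to compound 4 that is not expected to move it into the readable range. The estimate for compound 4 in this assay is 6000 nM, with a range from 1500 nM to 30000 nM, and the most likely outcome is that the assay again reports only a limit.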

Compound 4, half-maximal inhibitory concentration: 116 nM
Beside the measured number, compound 4's estimate is 52-fold (1.71 log units) above it, outside the stated range (below it).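

In this assay, the change from 6-chloropyridin-3-yl to pyridin-3-yl gives an at least 17-fold lower number from compound 2 to compound 4 (1.23 log units; beyond the scatter), the first step among these compounds that can be read. It shows that this one position, an aromatic carbon next to the ring nitrogen and para to a large group, matters a great deal in this series, and that a single chloro there separates a readable number from none. The true size of the step remains unknown, as compound 2 has only a limit and no number of its own: the limit of > 2000 nM in this assay, at which 3 of the 4 values shown sit.

The compounds shown leave open whether the loss of chloro is specific to that atom or whether any group on this carbon would have the same outcome, a question that fluoro, methyl, methoxy or an amine at that place would answer. They also leave open how the pyridin-3-yl group behaves on other linkers, as the step between the two amide compounds cannot be read and neither of them carries this group.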